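This account rests on a few compounds, and the source may have more. Where it says the series, first, only, none or still open, it means among the compounds named here.

Measured compounds:
Compound 1 `Nc1cc(OCc2cccc(-c3cccc(F)c3)c2)c2nn[nH]c2n1` gives 21 nM in an assay for inhibition of Myeloperoxidase (Homo sapiens), read by Amplex Red, with stated times of 10 min and 15 min; on this read-out lower numbers stand for stronger inhibition and higher numbers for weaker inhibition.
Compound 2 `Cn1ccc(-c2cccc(COc3cc(N)nc4[nH]nnc34)c2)n1` gives 21 nM in this assay.
Compound 3 `Cn1cc(-c2cccc(COc3cc(N)nc4[nH]nnc34)c2)cn1` gives 78 nM in this assay.

Compound 3 has the highest number of the three: the step from compound 1 is a 3.7-fold higher number from compound 1 to compound 3 (0.57 log units; beyond the scatter), and the step from compound 2 is a 3.7-fold higher number from compound 2 to compound 3 (0.57 log units; beyond the scatter), both beyond the scatter, while compounds 1 and 2 lie within the scatter of each other no change at the digits printed from compound 1 to compound 2 (within the scatter).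

Compound 4 `Nc1cc(OCc2cccc(-c3ccccc3F)c2)c2nn[nH]c2n1` has not yet been measured. It differs from compound 3 in one place: 2-fluorophenyl in place of 1-methyl-1H-pyrazol-4-yl on an aromatic carbon. For the measured compounds named here, the step that bears most directly on this is the one from compound 1 to compound 3, where a fluorophenyl gave way to the 1-methyl-1H-pyrazol-4-yl group and the number rose a 3.7-fold higher number from compound 1 to compound 3 (0.57 log units; beyond the scatter). Going by the values given here, compound 4 goes the other way, back to a fluorophenyl, although with the fluorine at a different position than in compound 1, and no measured step separates the two fluorophenyl isomers. Compound 4 is therefore expected to show a lower number than compound 3 in this assay, roughly reversing that step, as a 2.8-fold lower number from compound 3 to compound 4 (0.44 log units; beyond the scatter), because compound 1 gives 21 nM. Compound 4 is estimated at 28 nM, with a range from 10 nM to 80 nM.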

Compound 4, half-maximal inhibitory concentration: 160 nM
Compound 4: the middle estimate sits 5.7-fold (0.76 log units) below what was measured, outside the stated range (above it).
By their numbers in this assay, from the lowest: compounds 1 and 2 (each within the scatter of the next); then compound 3; then compound 4.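

In this assay, for the compounds shown here, the 2-fluorophenyl in place of 3-fluorophenyl gives a 7.6-fold higher number from compound 1 to compound 4 (0.88 log units; beyond the scatter), so this position responds to where the fluorine stands on the phenyl ring, a difference that the earlier compounds, with only one fluorophenyl isomer, could not reveal. A fluorophenyl group at this position therefore does not by itself match the pyrazoles: 2-fluorophenyl in place of 1-methyl-1H-pyrazol-4-yl gives a 2.1-fold higher number from compound 3 to compound 4 (0.31 log units; beyond the scatter), and in place of 1-methyl-1H-pyrazol-3-yl it gives a 7.6-fold higher number from compound 2 to compound 4 (0.88 log units; beyond the scatter), whereas the 3-fluorophenyl of compound 1 was level with the 1-methyl-1H-pyrazol-3-yl of compound 2 within the scatter. Nothing available here accounts for the gap between the two fluorophenyl isomers.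

The compounds shown leave open whether the rise in the number belongs to fluorine specifically or would also appear with 2-chlorophenyl or 2-methylphenyl at this place. Going by these compounds, they also do not tell how unsubstituted phenyl or 4-fluorophenyl would stand against the two fluorophenyl isomers, so the trend across the phenyl ring remains unknown.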